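Swapping methoxy for chloro on a hydroxamic acid inhibitor

This account rests on a few compounds, and the source may have more. Where it says the series, first, only, none or still open, it means among the compounds named here.

Measured so far in an assay on isolated protein for inhibition of histone deacetylase 8 (Homo sapiens), read by fluorescence, with a stated time of 90 min; on this read-out higher numbers stand for weaker inhibition and lower numbers for stronger inhibition:
Compound 1, `O=C(NO)c1ccc(Cl)c(NC(=O)c2ccc(-c3ccccc3)cc2)c1`, gives 450 nM.
Compound 2, `CSc1ccc(C(=O)NO)cc1NC(=O)c1ccc(-c2ccccc2)cc1`, gives 220 nM.
Compound 3, `COc1ccc(C(=O)NO)cc1NC(=O)c1ccc(-c2ccccc2)cc1Cl`, gives 1100 nM.

Among these three, compound 3 stands at the highest number, so it is the weakest inhibitor of the set; compound 1 sits nearer to it and compound 2 furthest away. Compound 4, `O=C(NO)c1ccc(Cl)c(NC(=O)c2ccc(-c3ccccc3)cc2Cl)c1`, is still to be measured. It differs from compound 3 in one spot: chloro in place of methoxy on an aromatic carbon. Going by the values given here, the one measured step at that same spot is a 2.0-fold lower number from compound 1 to compound 2 (0.31 log units; beyond the scatter), where a chloro gave way to a methylsulfanyl. Among the compounds with values here, no measured pair shows methoxy against chloro directly, and compound 3 differs from compound 1 in two places, so their values cannot be read as a single step. Compound 4 carries the same chloro at that spot as compound 1, which gave a lower number than compound 3. On that basis a modest drop in number is expected for compound 4, with wide uncertainty: a 1.8-fold lower number from compound 3 to compound 4 (0.26 log units; within the scatter). The estimate for compound 4 in this assay is 600 nM, with a likely range from 250 nM to 1500 nM.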

Compound 4, half-maximal inhibitory concentration: 780 nM
Beside the measured number, compound 4's estimate is 1.3-fold (0.11 log units) below it; the range from low to high includes it.
By their numbers in this assay, from the lowest: compound 2; then compounds 1, 4 and 3 (each within the scatter of the next, the first and the last beyond it).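

In this assay, going by these compounds alone, the first direct comparison of methoxy and chloro on the carbon para to the hydroxycarbamoyl group gives a 1.4-fold lower number from compound 3 to compound 4 (0.15 log units; within the scatter), so this swap cannot be told apart from repeat-measurement noise, even though the hydrogen-bond acceptor counted on methoxy is absent from chloro. The second new pair looks at a different place on the molecule and gives a 1.7-fold higher number from compound 1 to compound 4 (0.24 log units; within the scatter), so chloro in place of hydrogen there also stays within the scatter. Within the data shown here, that leaves a 2.0-fold lower number from compound 1 to compound 2 (0.31 log units; beyond the scatter) as the only step at the first carbon that lies beyond the scatter, and both of its compounds carry hydrogen at the second place.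

Nothing available here explains these small differences. From the compounds shown here alone, it remains open whether an amine, a carboxylic acid or a longer chain such as ethoxy on the carbon para to the hydroxycarbamoyl group would move the number beyond the scatter, and whether methylsulfanyl would give a similar step with the second chloro in place.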